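Swapping a Methyl for Hydrogen on an Aryl Oxygen

The source may hold more compounds than are shown below. What is called first, only, known or untested is meant among the compounds shown, and "the series" means these compounds.

Of the compounds shown here, three sharing one core have been tested in a functional assay on SF-268 cells (Homo sapiens) for inhibition, read by sulforhodamine B assay, with a stated time of 48 h; on this read-out lower numbers stand for stronger inhibition of growth and higher numbers for weaker inhibition of growth. Compound 1 `O=C(Nc1cccc(-n2cc(-c3ccncc3)c(-c3ccc(Cl)c(O)c3)n2)c1)Nc1cccc(C(F)(F)F)c1` gives 15800 nM, compound 2 `O=C(Nc1cccc(-n2cc(-c3ccncc3)c(-c3ccc(Cl)c(O)c3)n2)c1)Nc1ccc(Cl)c(Cl)c1` gives 10900 nM, and compound 3 `COc1cc(-c2nn(-c3cccc(NC(=O)Nc4ccc(Cl)c(C(F)(F)F)c4)c3)cc2-c2ccncc2)ccc1Cl` gives 9140 nM. Compound 3 has the lowest of these three numbers, but its gaps to compound 2 and to compound 1 stay within the scatter, so no order among them can be claimed. Among the compounds with values here, the single measured step, a 1.4-fold lower number from compound 1 to compound 2 (0.16 log units; within the scatter), concerns the group on the amide-type nitrogen and does not touch the change leading to compound 4 `O=C(Nc1cccc(-n2cc(-c3ccncc3)c(-c3ccc(Cl)c(O)c3)n2)c1)Nc1ccc(Cl)c(C(F)(F)F)c1`: hydrogen in place of methyl on an oxygen on an aromatic ring. Within the data shown here, compounds 1 and 2 already carry this hydroxy, yet they differ from compound 3 elsewhere as well, so no step bears directly on it. The expected movement is none beyond the scatter, a 1.1-fold higher number from compound 3 to compound 4 (0.04 log units; within the scatter). Compound 4 is therefore estimated at 10000 nM, within a range from 4000 nM to 25000 nM.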

Compound 4, concentration for total growth inhibition: 6980 nM
Beside the measured number, compound 4's estimate is 1.4-fold (0.16 log units) above it; the measured number falls inside the stated range.
By their numbers in this assay, from the lowest: compounds 4, 3, 2 and 1 (each within the scatter of the next, the first and the last beyond it).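

In this assay, going from methoxy to hydroxy on the aromatic ring gives a 1.3-fold lower number from compound 3 to compound 4 (0.12 log units; within the scatter), so the methyl on this oxygen can go without a clear change in the number. Trifluoromethyl in place of chloro gives a 1.6-fold lower number from compound 2 to compound 4 (0.19 log units; within the scatter), which also cannot be told from scatter. Only chloro in place of hydrogen, with a 2.3-fold lower number from compound 1 to compound 4 (0.35 log units; beyond the scatter), goes modestly beyond the scatter. As far as these compounds go, whether ethoxy or an amine in place of methoxy would shift the number remains open. No measurement offered here explains any of these steps.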